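This account rests on a few compounds, and the source may have more. Where it says the series, first, only, none or still open, it means among the compounds named here.

Series notes. In an assay on isolated protein for inhibition of retinal dehydrogenase 2 (Homo sapiens) (on this read-out lower numbers stand for stronger inhibition and higher numbers for weaker inhibition), compound 1 `CC(Sc1nc2nn(C3COC3)cc2c(=O)n1-c1ccccc1)c1ccccc1` gives 65 nM, the lowest of the three numbers shown, with compound 2 inside the scatter of it. Compound 2 `CC(Sc1nc2nn(C3(C)COC3)cc2c(=O)n1-c1ccccc1)c1ccccc1` gives 112 nM; the step of a 1.7-fold higher number from compound 1 to compound 2 (0.24 log units; within the scatter) follows methyl in place of hydrogen on a saturated ring carbon. Compound 3 `Cn1ncc2c(=O)n(-c3ccccc3)c(SCc3cccc(F)c3)cc21` gives 240 nM and differs from compound 1 in several places at once, so only the two values can be set side by side. Compound 4 `CC(Sc1nc2nn(C3COC3)cc2c(=O)n1-c1ccccc1)c1cccnc1` differs from compound 1 by pyridin-3-yl in place of phenyl on a saturated chain carbon bound to a saturated chain carbon and a sulfur. For the measured compounds named here, no measured step touches this place; the single measured step sits on the saturated ring and lies within the scatter. A step of a 1.4-fold higher number from compound 1 to compound 4 (0.14 log units; within the scatter) is therefore expected, with no direction beyond the scatter. Compound 4 is estimated at 90 nM, between 35 nM and 250 nM.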

Compound 4, half-maximal inhibitory concentration: 58 nM
Estimate against measurement, compound 4: 1.6-fold (0.19 log units) above, and the stated range covers the measured number.
By their numbers in this assay, from the lowest: compounds 4, 1 and 2 (each within the scatter of the next); then compound 3.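

For the compounds shown here, this is the first step read at the 1-phenylethyl group, on a saturated chain carbon bound to a saturated chain carbon and a sulfur. In this assay the step of a 1.1-fold lower number from compound 1 to compound 4 (0.05 log units; within the scatter) shows that pyridin-3-yl can stand in place of phenyl here, adding one hydrogen-bond acceptor with no shift beyond the scatter. Nothing available explains this result.

Still open, going by these compounds, is whether pyridin-4-yl, or a phenyl carrying an amine or a carboxylic acid, would read the same at this position.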